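This account rests on a few compounds, and the source may have more. Where it says the series, first, only, none or still open, it means among the compounds named here.

Measured compounds:
- compound 1 `Cn1nc2c(=O)n(CC3(O)CCN(Cc4ccc(-c5cnco5)cc4Cl)CC3)cnc2c1-c1ccc(CN)cc1` gives 71.6 nM in an assay on isolated protein for inhibition of ubiquitin carboxyl-terminal hydrolase 7 (Homo sapiens), with stated times of 30 min and 2 h; on this read-out higher numbers stand for weaker inhibition and lower numbers for stronger inhibition
- compound 2 `Cn1nc2c(=O)n(CC3(O)CCN(Cc4ccc(-c5ccco5)cc4Cl)CC3)cnc2c1-c1ccc(CNC=O)cc1` gives 20.9 nM
- compound 3 `Cn1nc2c(=O)n(CC3(O)CCN(Cc4ccc(C5CCCO5)cc4Cl)CC3)cnc2c1-c1ccc(CN)cc1` gives 3820 nM

Compound 2 has the lowest number of the three, and both other compounds lie beyond the scatter from it: compound 1 is nearest, compound 3 furthest. The unmeasured compound 4 `CN(C)Cc1ccc(-c2c3ncn(CC4(O)CCN(Cc5ccc(-c6ccco6)cc5Cl)CC4)c(=O)c3nn2C)cc1` differs from compound 2 in one place: dimethylamino in place of formylamino on a saturated chain carbon bound to an aromatic carbon.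

Going by the values given here, only one measured step exists here, a 53-fold higher number from compound 1 to compound 3 (1.73 log units; beyond the scatter), and it sits at a different part of the molecule, so it says nothing about the chain carbon changed in compound 4. Compounds 1 and 2 differ in two places at once, one of them at this same chain carbon, so their two values cannot be split into separate contributions. Among the compounds with values here, with no step bearing directly on this change, the expectation is a step in this assay that stays within the scatter, with a wide range to either side. Compound 4 is therefore estimated at 35 nM (range 10 nM to 130 nM), which means an expected step of a 1.7-fold higher number from compound 2 to compound 4 (0.22 log units; within the scatter).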

Compound 4, half-maximal inhibitory concentration: 131 nM
Estimate against measurement, compound 4: 3.7-fold (0.57 log units) below, outside the stated range (above it).
By their numbers in this assay, from the lowest: compound 2; then compounds 1 and 4 (each within the scatter of the next); then compound 3.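

In this assay, going by these compounds alone, going from formylamino to dimethylamino gives a 6.3-fold higher number from compound 2 to compound 4 (0.80 log units; beyond the scatter) and is the first reading of a change at this chain carbon alone; compound 1 and compound 2 differ in two places at once. The step lies beyond the usual scatter, so the group held by this chain carbon does matter in this series, even though the two groups have the same number of heavy atoms. The swap also removes a hydrogen-bond donor and a double bond, and nothing measured here links the higher number to either difference.

Acetylamino or methylamino on the same chain carbon, with the rest of compound 2 unchanged, would help show which difference counts. On these data alone, whether this step holds on other compounds also stays open.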